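This account rests on a few compounds, and the source may have more. Where it says the series, first, only, none or still open, it means among the compounds named here.

Compound 1 `CN(C)c1ccc(C(=O)N(CCC(=O)NCc2ccc(Cl)cc2)Cc2ccc(C(=O)NO)cc2)cc1`: 610 nM
Compound 2 `CN(C)c1ccc(C(=O)N(CCC(=O)NCc2ccccc2)Cc2ccc(C(=O)NO)cc2)cc1`: 1160 nM

Both compounds were tested in a functional assay on CHP-134 cells (Homo sapiens) for antiproliferative activity, with a stated time of 72 h; on this read-out lower numbers stand for stronger inhibition and higher numbers for weaker inhibition. In this assay, among the measured compounds shown here, compound 2 gives 1160 nM, and the only other number available for comparison is that of compound 1, at 610 nM. For the measured compounds named here, the single measured step, a 1.9-fold higher number from compound 1 to compound 2 (0.28 log units; within the scatter), lies within the scatter, so these two values cannot be told apart.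

The next compound is compound 3 `Cc1ccc(NC(=O)CCN(Cc2ccc(C(=O)NO)cc2)C(=O)c2ccc(N(C)C)cc2)cc1`, and its difference from compound 2 is 4-methylphenyl in place of benzyl on an amide-type nitrogen. In short, 4-methylphenyl stands in place of benzyl on an amide-type nitrogen. The measured step is a different kind of change, hydrogen in place of chloro on an aromatic carbon, so it offers only a loose guide. Going by the values given here, no measured compound carries 4-methylphenyl, and the data therefore favour no direction. With only a 1.9-fold higher number from compound 1 to compound 2 (0.28 log units; within the scatter) to go on, no step beyond the scatter is expected. The expected step is a 1.1-fold lower number from compound 2 to compound 3 (0.02 log units; within the scatter). In this assay, compound 3 is estimated at about 1100 nM, with an expected range of 400 nM to 3000 nM.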

Compound 3, half-maximal inhibitory concentration: 540 nM
Beside the measured number, compound 3's estimate is 2.0-fold (0.31 log units) above it; measured number inside the range.
By their numbers in this assay, from the lowest: compounds 3, 1 and 2 (each within the scatter of the next, the first and the last beyond it).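

In this assay, among the compounds shown here, replacing benzyl with 4-methylphenyl on the amide-type nitrogen gives a 2.1-fold lower number from compound 2 to compound 3 (0.33 log units; beyond the scatter) and so becomes the first step in this small set to pass beyond the scatter, though only modestly. The two groups have the same atom count and the same kind of aromatic ring, so even a change that leaves these counts untouched can register at this position. Compared with the 4-chlorobenzyl group of compound 1, the same position gives a 1.1-fold lower number from compound 1 to compound 3 (0.05 log units; within the scatter) with 4-methylphenyl, so these two compounds cannot be told apart, and nothing available explains why benzyl and 4-methylphenyl differ.

The compounds shown leave open whether the methyl group or the shorter link from the amide-type nitrogen to the aromatic ring accounts for the step, which a plain phenyl group could help to separate. They also leave open how a longer chain, such as 2-phenylethyl, or a 4-chlorophenyl group would behave at this position.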